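Swapping the piperidine for a difluorophenoxy on a sulfamoyl carbamate

A few compounds are considered here, and "the series" means these few. Any claim that something is new, unique, unknown or untested is made for them only; others in the source may bear on it.

Measured compounds in an assay on liver for inhibition of sterol O-acyltransferase 1 (Rattus norvegicus), using microsomes; a lower number here means a stronger inhibitor, a higher number a weaker inhibitor:
compound 1, `CC(C)c1cccc(C(C)C)c1OC(=O)NS(=O)(=O)N1CCCCC1`, > 100000 nM
compound 2, `CCCCCCCCN(C)S(=O)(=O)NC(=O)Oc1c(C(C)C)cccc1C(C)C`, 22000 nM
compound 3, `CCCCCCCCN(CCCCCCCC)S(=O)(=O)NC(=O)Oc1c(C(C)(C)C)cc(C)cc1C(C)(C)C`, 2700 nM

All three compounds share a carbamate whose nitrogen carries a sulfonyl group, and they differ in what sits on that sulfonyl sulfur and in the substituents on the phenol. Compound 1 is reported only as a limit: in this assay compound 1 gives > 100000 nM, which is the upper boundary of what the measurement can resolve and not a true number. This places compound 1 at the limit of > 100000 nM in this assay, at which 1 of the 3 values shown sits. Compound 2, with a methyl-octyl-amino group on the sulfur, gives 22000 nM, and compound 3, with two octyl chains, gives 2700 nM.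

Compound 4, `CC(C)c1cccc(C(C)C)c1OC(=O)NS(=O)(=O)Oc1ccc(F)cc1F`, has not yet been measured. It differs from compound 1 in one place: 2,4-difluorophenoxy in place of piperidin-1-yl on a sulfonyl sulfur. Going by the values given here, no measured pair in this set shows exactly this kind of change, so its effect is uncertain. Because compound 1 sits at the limit (the limit of > 100000 nM in this assay, at which 1 of the 3 values shown sits), any real number for compound 4 would be a step downward, though how far cannot be anchored. Compound 4 is expected to land near 30000 nM, within a range of 8000 nM to 100000 nM, an estimated step from compound 1 to compound 4 of an at least 3.3-fold lower number from compound 1 to compound 4 (0.52 log units; beyond the scatter).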

Compound 4, half-maximal inhibitory concentration: > 50000 nM
Compound 4 was reported as a limit; the forecaster's own chance of this, stated with the estimate: 35%; at least 1.6-fold (0.22 log units) between middle value and limit.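

In this assay compound 4 gives > 50000 nM, which is a limit and not a number. Going by these compounds alone, compound 1 also stands only as a limit, > 100000 nM, so no step between compound 1 and compound 4 can be read. From the compounds shown here alone, whether 2,4-difluorophenoxy or piperidin-1-yl on the sulfonyl sulfur gives the stronger inhibitor remains open.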